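Closing the Diethylamino of Compound 3 into a Ring

This account rests on a few compounds, and the source may have more. Where it says the series, first, only, none or still open, it means among the compounds named here.

Measured so far:
compound 1 `CCCNc1nc(=O)c2cc(C(F)(F)F)cc([N+](=O)[O-])c2s1` — > 100000 nM
compound 2 `CCCCNc1nc(=O)c2cc(C(F)(F)F)cc([N+](=O)[O-])c2s1` — > 100000 nM
compound 3 `CCN(CC)c1nc(=O)c2cc(C(F)(F)F)cc([N+](=O)[O-])c2s1` — > 100000 nM

In an ADME assay on Vero cells (Chlorocebus sabaeus) for cytotoxicity, read by MTT assay, with a stated time of 72 h (on this read-out lower numbers stand for stronger inhibition and higher numbers for weaker inhibition), compound 1 gives > 100000 nM, which is a limit of the assay and not a number. Compound 2 likewise gives > 100000 nM, again a limit. Compound 3 gives > 100000 nM, also a limit. All three therefore sit at the limit of > 100000 nM in this assay, at which 3 of the 3 values shown sit, so compound 3 stands nowhere distinct from the other two. The steps a step that the two limits leave unreadable from compound 1 to compound 2, a step that the two limits leave unreadable from compound 1 to compound 3 and a step that the two limits leave unreadable from compound 2 to compound 3 cannot be read from these limits.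

Compound 4 `O=c1nc(N2CCCC2)sc2c([N+](=O)[O-])cc(C(F)(F)F)cc12` differs from compound 3 by pyrrolidin-1-yl in place of diethylamino on an aromatic carbon. Every measured step among compounds 1, 2 and 3 is unreadable, so none gives a size to lean on; what they do show is that three different amino groups on this core all reached the same limit. For compound 4 the expectation is therefore no step beyond the scatter, a step that the limit leaves unreadable from compound 3 to compound 4, with the likely outcome again a limit. Compound 4 is thus estimated at 150000 nM, within 50000 nM to 500000 nM.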

Compound 4, half-maximal inhibitory concentration: > 100000 nM
Compound 4 ended at the assay's limit (the forecaster's own chance of this, stated with the estimate: 80%); the middle value is on the limit's open side.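

Going by these compounds alone, compounds 1, 2, 3 and 4 all end at the same limit of the assay, not at a number, so no step to compound 4 can be read: the limit of > 100000 nM in this assay, at which 4 of the 4 values shown sit. The compounds shown leave open how far apart these four truly lie, and whether any amino group on the shared core would give a measurable value.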